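Series notes: bromo to methoxy on the shared core

The source may report more compounds than this note shows. Statements on the series, on what has been measured and on what is new or still open speak of the compounds shown alone.

Going by the values given here, compound 3 `COc1cc(/C(Cl)=C/C=C(\C#N)C(=O)c2c[nH]c3ccc(Br)cc23)cc(OC)c1OC` gives 36.7% in a functional assay for inhibition, read by Griess assay, with a stated time of 150 min, tested at 1 mM (a lower number here means less inhibition, a higher number more inhibition at the concentration tested (going by the name of the read-out)), the lowest of the three numbers so far; compound 1 `COc1cc(/C(Cl)=C/C=C(\C#N)C(=O)c2c[nH]c3ccccc23)cc(OC)c1OC` gives 73.3% and compound 2 `COc1ccc2[nH]cc(C(=O)/C(C#N)=C/C=C(\Cl)c3ccc(OC)c(OC)c3)c2c1` gives 74.2%, each beyond the scatter above compound 3. Among the compounds with values here, the only one-place step measured in this assay is a number 36.6 percentage points lower from compound 1 to compound 3 (beyond the scatter), a large drop. The step to compound 4 `COc1ccc2[nH]cc(C(=O)/C(C#N)=C/C=C(\Cl)c3cc(OC)c(OC)c(OC)c3)c2c1` is methoxy in place of bromo on an aromatic carbon. Within the data shown here, no measured step leads from bromo or hydrogen to methoxy at this place, so the expectation rests on two observations: the large drop in this assay on introducing bromo, and the fact that compound 2, which carries a methoxy on its core, gives a value within the scatter of compound 1. The drop is therefore expected to be undone rather than deepened. Compound 4 is expected to give 72%, with a range of 58% to 84%. This corresponds to an expected step of a number 35.3 percentage points higher from compound 3 to compound 4 (beyond the scatter).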

Compound 4, a percentage reported as inhibition, at one concentration (the size of the read-out at that concentration, not a potency): 68.3%
Compound 4: the middle estimate sits 3.7 percentage points above what was measured, within the range that was stated.
By their numbers in this assay, from the lowest: compound 3; then compounds 4, 1 and 2 (each within the scatter of the next).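

At this place on the shared core, bromo to methoxy gives in this assay a number 31.6 percentage points higher from compound 3 to compound 4 (beyond the scatter), while methoxy in place of hydrogen at the same place gives a number 5 percentage points lower from compound 1 to compound 4 (within the scatter), so among these compounds the loss goes with bromo and not with every group put here. Methoxy in place of hydrogen at another place gives a number 5.9 percentage points lower from compound 2 to compound 4 (within the scatter), so this added methoxy also leaves no readable change. Nothing at hand bears on why bromo and methoxy differ here.

As far as these compounds go, with only hydrogen, bromo and methoxy at this place, it remains open whether fluoro, an amine or a carboxylic acid would follow bromo or methoxy. From the compounds shown here alone, all readings come from a single concentration, so any difference in potency between compound 1 and compound 4 also remains open.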